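Notes on a methoxy-to-hydrogen step in the series

The source may report more compounds than this note shows. Statements on the series, on what has been measured and on what is new or still open speak of the compounds shown alone.

Among the compounds with values here, compound 1 `COc1ccc(-c2cnc(NC(=O)CCCCCCNC(=O)C(O)(O)C(F)(F)F)s2)cc1` carries the lowest of the two numbers measured so far in an assay on isolated protein for inhibition of histone deacetylase 8 (Homo sapiens), read by chemiluminescence, with a stated time of 3 h (a lower number here means a stronger inhibitor, a higher number a weaker inhibitor), giving 13000 nM. Compound 2 `COc1ccc(NC(=O)CCCCCCNC(=O)C(O)(O)C(F)(F)F)cc1` is the nearest neighbour; in this assay compound 2 gives 51000 nM, a gap beyond the scatter. Compound 3 `O=C(CCCCCCNC(=O)C(O)(O)C(F)(F)F)Nc1ncc(-c2ccccc2)s1` differs from compound 1 by hydrogen in place of methoxy on an aromatic carbon, or, cut one bond further out, 4-methoxyphenyl to phenyl. Within the data shown here, no measured pair shows this change, so only a small step is expected, toward a slightly higher number or none beyond the scatter. The step of a 1.2-fold higher number from compound 1 to compound 3 (0.09 log units; within the scatter) is expected to lie within the scatter. Compound 3 is estimated at 16000 nM in this assay, between 6000 nM and 45000 nM.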

Compound 3, half-maximal inhibitory concentration: 21000 nM
Estimate against measurement, compound 3: 1.3-fold (0.12 log units) below, and the stated range covers the measured number.
By their numbers in this assay, from the lowest: compounds 1 and 3 (each within the scatter of the next); then compound 2.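

In this assay, within the data shown here, hydrogen in place of methoxy on an aromatic carbon gives a 1.6-fold higher number from compound 1 to compound 3 (0.21 log units; within the scatter) and is the first measured pair at this position. The 4-methoxyphenyl and phenyl forms therefore cannot be told apart in this assay, and the methoxy group is not required for a number in this range. No measurement available here bears on the reason for this result. Still open, on these data alone, is how a chlorine atom, an amine or a carboxylic acid at this position would read. As far as these compounds go, a longer alkoxy chain there also remains open.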